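Methyl for fluoro exchange: stability notes on the series

A few compounds are considered here, and "the series" means these few. Any claim that something is new, unique, unknown or untested is made for them only; others in the source may bear on it.

Three members of the series have been measured: compound 1 `CC(=O)Nc1cc(-c2ccc(OC[C@@H](N)CC(C)C)c(F)c2)ccn1`, compound 2 `COC(=O)Nc1cc(-c2ccc(OC[C@@](C)(N)CC(C)C)c(C)c2)ccn1` and compound 3 `COC(=O)Nc1cc(-c2ccc(OC[C@@](C)(N)CC(C)C)c(F)c2)ccn1`. A fourth, compound 4 `CC(=O)Nc1cc(-c2ccc(OC[C@@H](N)CC(C)C)c(C)c2)ccn1`, is still to be measured. In an ADME assay on microsomes from liver (Mus musculus) for metabolic stability, read by LC-MS, using NADPH, with a stated time of 10 min, tested at 0.5 uM (on this read-out lower numbers stand for a less stable compound and higher numbers for a more stable compound), compound 1 gives 79%. In this assay compound 2 gives 75%, and compound 3 gives 71%. All three values lie within the scatter of one another, so no order among them is claimed.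

Compound 3 and compound 2 differ in one place: methyl in place of fluoro on an aromatic carbon. The measured step was a number 4 percentage points higher from compound 3 to compound 2 (within the scatter). Compound 1 and compound 4 differ in one place as well: methyl in place of fluoro on an aromatic carbon. The surroundings of the place are not identical in the two pairs: in the measured pair the carbon is ortho to a (2-amino-2,4-dimethylpentyl)oxy group, in the new pair it is ortho to a (2-amino-4-methylpentyl)oxy group, so the change is of the same kind rather than the same. The difference between the core of compound 1 and the core of compound 3 is not broken down here.

The step from compound 1 to compound 4 in this assay is expected to be a number 2 percentage points higher from compound 1 to compound 4 (within the scatter), which rests on the measured step of a number 4 percentage points higher from compound 3 to compound 2 (within the scatter) lying within the scatter. For compound 4 the value in this assay is estimated at 81%, expected to fall between 70% and 91%.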

Compound 4, percent of the compound remaining: 64%
Compound 4: the middle estimate sits 17 percentage points above what was measured; measured number below the stated range.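

In this assay, the exchange of fluoro for methyl on the aromatic carbon gives a number 15 percentage points lower from compound 1 to compound 4 (beyond the scatter), and the same change on the other core does not give a step of that kind: the same change on two cores in this assay, a number 4 percentage points higher (within the scatter) from compound 3 to compound 2 and a number 15 percentage points lower (beyond the scatter) from compound 1 to compound 4, 19 percentage points apart, beyond the scatter of two such steps. Across these two pairs, then, the step does not carry over from one core to the other as a fixed increment, and a step measured on the core of compound 3 is a poor guide to the step on the core of compound 1. This rests on one pair per core and does not show which of the differences between the cores goes with the gap, nor does it give a cause for the lower number of compound 4.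

The compounds shown leave open whether the two differences between the cores act singly or only together, since no pair here separates the (2-amino-4-methylpentyl)oxy group from the (2-amino-2,4-dimethylpentyl)oxy group on an otherwise unchanged structure. They also leave open how other small groups on the same aromatic carbon, such as chloro or methoxy, would behave on each core, and whether the split between the cores would hold for them.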